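Chain variation on a shared core: compound 3 before measurement

The compounds below may be only part of what the source reports. "The series", "measured", "known", "first", "only" and "open" are said of these compounds alone.

Measured so far:
compound 1 `CCCCNc1ccc([N+](=O)[O-])cc1S(N)(=O)=O` gives 4.7%
compound 2 `CCCCCCCCNc1ccc([N+](=O)[O-])cc1S(N)(=O)=O` gives 5.8%

In an assay on HEK293 cells for inhibition of solute carrier family 12 member 2 (Homo sapiens), read by fluorescence, with a stated time of 30 min, tested at 100 uM (a lower number here means a weaker effect, a higher number a stronger effect of the compound at the concentration tested), compound 1 gives 4.7% and compound 2 gives 5.8%. Compound 2 stands beside compound 1 rather than apart from it: the step of a number 1.1 percentage points higher from compound 1 to compound 2 (within the scatter) is within the scatter, so the two compounds are not separated on these numbers, and both chains leave this assay essentially unmoved at the concentration tested.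

Compound 3 `CC(C)(C)CCNc1ccc([N+](=O)[O-])cc1S(N)(=O)=O` has not yet been measured. It differs from compound 2 by tert-butyl in place of hexyl on a saturated chain carbon, two bonds along the chain from a nitrogen on an aromatic ring. Within the data shown here, the only measured step that bears on a change of this chain is a number 1.1 percentage points higher from compound 1 to compound 2 (within the scatter), and it was within the scatter. That step extended the chain, whereas the present change replaces hexyl with tert-butyl, so it bears on the question only loosely. Nothing measured here points to a step beyond the scatter in either direction, so the expected step of a number 0.8 percentage points lower from compound 2 to compound 3 (within the scatter) is flat. Compound 3 is therefore estimated at 5%, between -3% and 15%.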

Compound 3, a percentage reported as inhibition, at one concentration (the size of the read-out at that concentration, not a potency): 14.5%
Estimate against measurement, compound 3: 9.5 percentage points below; measured number inside the range.
By their numbers in this assay, from the lowest: compounds 1, 2 and 3 (each within the scatter of the next).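

In this assay, among these compounds, hexyl gives way to tert-butyl on a saturated chain carbon, two bonds along the chain from a nitrogen on an aromatic ring, with a number 8.7 percentage points higher from compound 2 to compound 3 (within the scatter); this is the first change to alter the form of the chain end and not only its length. Ethyl gives way to tert-butyl at the same place with a number 9.8 percentage points higher from compound 1 to compound 3 (within the scatter), so with both steps inside the scatter, the tert-butyl compound is not separated from either of the other two, and this position accepts the change without a readable shift in either direction. No measurement bears on why these three compounds read as they do at the concentration tested.

Still open, going by these compounds, is whether any group at this chain end can lift the read-out in this assay clearly beyond the scatter, for example a carboxylic acid, an amine or a phenyl ring in place of tert-butyl. The compounds shown also leave open what the nitro group and the sulfonamide of the shared core contribute, since both stay unchanged throughout.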